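This account rests on a few compounds, and the source may have more. Where it says the series, first, only, none or still open, it means among the compounds named here.

Going by the values given here, compound 1 `COc1cc(-c2cc(/C=C/C(=O)c3ccc(N)cc3)[nH]n2)cc(OC)c1OC` gives 94% in a functional assay on A549 cells (Homo sapiens) for cytotoxicity, read by sulforhodamine B assay, with a stated time of 48 h, tested at 0.1 uM (on this read-out higher numbers stand for a weaker effect at the one concentration tested and lower numbers for a stronger effect), and stands lowest of the two numbers so far; its nearest neighbour, compound 2 `COc1ccc(C(=O)/C=C/c2cc(-c3cc(OC)c(OC)c(OC)c3)n[nH]2)cc1OC`, gives 98% in this assay, and the step of a number 4 percentage points higher from compound 1 to compound 2 (within the scatter) is within the scatter. Compound 3 `COc1cc(-c2cc(/C=C/C(=O)c3ccc(F)c(F)c3)[nH]n2)cc(OC)c1OC` has not yet been measured; it differs from compound 1 by 3,4-difluorophenyl in place of 4-aminophenyl on a carbonyl carbon. Among the compounds with values here, the only measured step at that same carbonyl carbon, a number 4 percentage points higher from compound 1 to compound 2 (within the scatter), stayed within the scatter, so for compound 3 no step beyond the scatter is expected in this assay, with a number 1 percentage points higher from compound 1 to compound 3 (within the scatter). Compound 3 is therefore estimated at 95%, from 84% to 100%.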

Compound 3, a percentage reported as activity, at one concentration (the size of the read-out at that concentration, not a potency): 98%
Compound 3: the middle estimate sits 3 percentage points below what was measured; measured number inside the range.
By their numbers in this assay, from the lowest: compounds 1, 2 and 3 (each within the scatter of the next).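

At the carbonyl carbon, 3,4-difluorophenyl in place of 4-aminophenyl gives, in this assay, a number 4 percentage points higher from compound 1 to compound 3 (within the scatter), and 3,4-difluorophenyl in place of 3,4-dimethoxyphenyl gives no change at the digits printed from compound 2 to compound 3 (within the scatter). All three groups at this position therefore read alike, although 4-aminophenyl has 1 hydrogen-bond donor and 3,4-difluorophenyl has 0 hydrogen-bond donors. No supporting evidence bears on this result.

The compounds shown leave open whether any group at this carbonyl carbon gives a step beyond the scatter, for instance a carboxylic acid on the phenyl ring or a longer alkyl chain in place of the phenyl ring.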